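Compound 4: a longer hydroxylated chain on the core of compound 2

The source may hold more compounds than are shown below. What is called first, only, known or untested is meant among the compounds shown, and "the series" means these compounds.

Compound 2 `CC(C)(C)[Si](C)(C)O[C@H]1CCCO[C@@H]1CC=O` holds the lowest number of the two compounds that have a reported value in a functional assay on MCF7S cells (Homo sapiens); a lower number here means a stronger inhibitor of growth, a higher number a weaker inhibitor of growth; in this assay compound 2 gives 21000 nM. Its hydroxymethyl counterpart compound 1 `CC(C)(C)[Si](C)(C)O[C@H]1CCCO[C@@H]1CCO` gives 55000 nM, and the step between them reads a 2.6-fold lower number from compound 1 to compound 2 (0.42 log units; beyond the scatter). Compound 3 `COC(=O)/C=C/C[C@H]1OCCC[C@@H]1OC(=O)c1ccccc1`, which carries a benzoate and an unsaturated ester on the shared core, is reported in this assay as "not active" (no number reported), without a number.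

Compound 4 `CC(C)(C)[Si](C)(C)O[C@H]1CCCO[C@@H]1C/C=C/CO` differs from compound 2 in one place: 3-hydroxyprop-1-en-1-yl in place of formyl on a saturated chain carbon bound to a saturated ring carbon. The chain thus regains a hydroxyl group, now at the end of the 3-hydroxyprop-1-en-1-yl group, together with one more double bond outside aromatic rings.

For the measured compounds named here, only the step of a 2.6-fold lower number from compound 1 to compound 2 (0.42 log units; beyond the scatter) bears on this change, and it runs the other way: trading the hydroxyl-bearing chain for a formyl gave a modestly lower number. Going by the values given here, no measured pair tests a chain lengthened by this amount, so the size of the expected move rests on that single step alone. A modest rise in the number for compound 4 in this assay, back toward compound 1, is therefore expected. The estimate for compound 4 is 40000 nM. Its expected range runs from 15000 nM to 110000 nM. This corresponds to an expected step of a 1.9-fold higher number from compound 2 to compound 4 (0.28 log units; within the scatter).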

Compound 4, concentration for 50% growth inhibition: 25000 nM
Compound 4: middle estimate off by 1.6-fold (0.20 log units), on the high side; the range from low to high includes it.
By their numbers in this assay, from the lowest: compounds 2 and 4 (each within the scatter of the next); then compound 1.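

In this assay, the exchange of formyl for 3-hydroxyprop-1-en-1-yl on a saturated chain carbon bound to a saturated ring carbon gives a 1.2-fold higher number from compound 2 to compound 4 (0.08 log units; within the scatter), so the formyl group is not needed to hold the number at this level, and this place accepts a longer chain ending in a hydroxyl group. The exchange of hydroxymethyl for the same group gives a 2.2-fold lower number from compound 1 to compound 4 (0.34 log units; beyond the scatter), so the earlier step from compound 1 to compound 2 can no longer be read as a simple penalty for a hydroxyl-bearing chain, with compound 4 standing against that reading. Nothing available explains why these two hydroxyl-bearing chains differ.

Still open, from the compounds shown here alone, is whether the double bond or the added length separates compound 4 from compound 1, which a saturated 3-hydroxypropyl chain at this place would help settle. Also open, going by these compounds, is how a carboxylic acid or an amine at the end of this chain would read in this assay, and whether any such group moves the number well beyond the narrow span seen so far.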